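From Chloro to Methyl: What Compound 4 Might Show

A few compounds are considered here, and "the series" means these few. Any claim that something is new, unique, unknown or untested is made for them only; others in the source may bear on it.

Of the compounds shown here, three sharing one core have been measured in a functional assay on CHO cells for agonist activity at Alpha-2C adrenergic receptor (Homo sapiens); a lower number here means that less compound is needed, a higher number that more compound is needed for the effect. Compound 1 `CSc1ccc(C)cc1NCC1=NCCN1` gives 8.91 nM, compound 3 `CSc1cc(F)ccc1NCC1=NCCN1` gives 100 nM, and compound 2 `CS(=O)(=O)c1ccc(Cl)cc1NCC1=NCCN1` gives 794 nM. Compound 2 thus stands at the highest of the three numbers: its nearest neighbour is compound 3, whose number is lower by a margin beyond the usual scatter, and compound 1 lies furthest away, lower still. Compound 4 `Cc1ccc(S(C)(=O)=O)c(NCC2=NCCN2)c1` has not yet been measured. It differs from compound 2 in one place: methyl in place of chloro on an aromatic carbon. Within the data shown here, no pair of measured compounds differs in just one place, so there is no step of this kind to lean on, and the two compounds bearing methylthio, compound 1 and compound 3, offer no direct reading of this exchange. The account therefore expects only a small step in this assay, leaning toward a lower number yet possibly within the scatter, a 1.6-fold lower number from compound 2 to compound 4 (0.20 log units; within the scatter). For compound 4 the estimated value in this assay is 500 nM, with a range from 150 nM to 1600 nM.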

Compound 4, half-maximal effective concentration: 1120 nM
The estimate for compound 4 lay 2.2-fold (0.35 log units) below the measured number; low and high end bracket the measured number.
By their numbers in this assay, from the lowest: compound 1; then compound 3; then compounds 2 and 4 (each within the scatter of the next).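

In this assay, the exchange of chloro for methyl on the aromatic carbon para to the methylsulfonyl group gives a 1.4-fold higher number from compound 2 to compound 4 (0.15 log units; within the scatter) and so stays within the scatter: with methylsulfonyl present, this position does not separate the two groups. Among these compounds, the sulfur substituent is a different matter, for methylsulfonyl in place of methylsulfanyl gives a 130-fold higher number from compound 1 to compound 4 (2.10 log units; beyond the scatter) and lies beyond the scatter, a first direct reading of that exchange. Nothing available gives a reason for either step.

On these data alone, it remains open whether chloro and methyl would also read alike with methylsulfanyl in place of methylsulfonyl. As far as these compounds go, it is equally open whether an amine, a methoxy group or a longer alkyl chain on this aromatic carbon would move the number beyond the scatter.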